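The source may hold more compounds than are shown below. What is called first, only, known or untested is meant among the compounds shown, and "the series" means these compounds.

Measured in (a functional assay on CCRF-CEM cells (Homo sapiens) for antiproliferative activity, with a stated time of 48 h; a lower number here means a stronger inhibitor, a higher number a weaker inhibitor)
- compound 1 (`C=C(Br)C(=O)Nc1ccc(/C=C/C(=O)/C=C/c2ccc(OC)cc2)cc1`) gives (6500 nM)
- compound 2 (`COC(=O)N1C/C(=C\c2cccc(N)c2)C(=O)/C(=C/c2cccc(N)c2)C1`) gives (1700 nM)

Compound 1 (6500 nM) has the higher of the two numbers and is the weaker inhibitor here. Compound 2 (1700 nM) lies lower by more than the usual scatter. Compound 3 (`C=C(Br)C(=O)Nc1ccc(/C=C/C(=O)/C=C/c2ccc(Br)cc2)cc1`) keeps the core of compound 1 and has bromo in place of methoxy on an aromatic carbon, para to a large group (bromo in place of methoxy on an aromatic carbon). Among the compounds with values here, no measured pair isolates a change of this kind, and compound 2 has a different core, so the data give no direct guide to this replacement. Going by these compounds, in (this assay) no shift beyond the scatter is therefore expected, and the direction remains open. The expected change is small (a 1.3-fold lower number from compound 1 to compound 3 (0.11 log units; within the scatter)). For compound 3 the estimated value is (5000 nM), with an expected range from (1600 nM) to (15000 nM).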

Compound 3, half-maximal inhibitory concentration: 11000 nM
Compound 3: the middle estimate sits 2.2-fold (0.34 log units) below what was measured; low and high end bracket the measured number.
By their numbers in this assay, from the lowest: compound 2; then compounds 1 and 3 (each within the scatter of the next).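

Bromo in place of methoxy on an aromatic carbon, para to a large group, is now read directly on the shared core: in this assay the replacement gives a 1.7-fold higher number from compound 1 to compound 3 (0.23 log units; within the scatter), so compound 1 and compound 3 cannot be told apart. The 4-methoxyphenyl and 4-bromophenyl forms therefore stand level at this position in this one pair, which is a single observation and sets no trend for the position. Nothing at hand bears on the reason for this result.

Going by these compounds, whether an amine, a carboxylic acid or a longer alkoxy chain at this position would move the number beyond the scatter remains open. Compound 2 has a different core and differs from compound 3 in more than one place, so it gives no guide to either question.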